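A few compounds are considered here, and "the series" means these few. Any claim that something is new, unique, unknown or untested is made for them only; others in the source may bear on it.

Of the compounds shown here, three with a shared core have been tested in an ADME assay on HCC95 cells (Homo sapiens) for inhibition, read by CellTiter-Glo, with a stated time of 72 h; on this read-out higher numbers stand for an effect only at larger amounts of compound and lower numbers for an effect already at smaller amounts. Compound 1 `Cc1cccc(C(=O)N[C@@H]2C(=O)Nc3c(c(C)nn3C3CCCC3)[C@@H]2c2ccc(F)cc2)c1` gives > 25000 nM, which is a limit of the assay and not a number. Compound 2 `CCOC1=Nc2c(c(C)nn2-c2ccccc2)[C@H](c2ccc(F)cc2)[C@@H]1NC(=O)c1cccc(C)c1` gives > 25000 nM, and this too is a limit. Compound 3 `CCN1C(=O)[C@@H](NC(=O)c2cccc(C)c2)[C@@H](c2ccc(F)cc2)c2c(C)nn(C3CC3)c21` gives > 25000 nM, again a limit. Compound 3 therefore has no exact number and stands with the other two at the limit of > 25000 nM in this assay, at which 3 of the 3 values shown sit.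

The next compound, compound 4 `CCCn1nc(C)c2c1N(CC)C(=O)[C@@H](NC(=O)c1cccc(C)c1)[C@H]2c1ccc(F)cc1`, carries propyl in place of cyclopropyl on an aromatic nitrogen. For the measured compounds named here, no two tested compounds differ in just one place, so there is no measured step to serve as a guide. The expectation rests on compound 3 and its limit of > 25000 nM. In this assay no change beyond the scatter is expected in either direction, and the estimated move is a number no higher from compound 3 to compound 4 (the limit leaves the size open). Compound 4 is estimated at 25000 nM, with an expected range from 12000 nM to 50000 nM.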

Compound 4, half-maximal effective concentration: > 25000 nM
Compound 4: no number, only a limit; the forecaster's own chance of this, stated with the estimate: 85%; the middle value lies on the limit itself.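

Compound 3 and compound 4 give no readable step for propyl in place of cyclopropyl on an aromatic nitrogen, because both results are limits and not numbers: the limit of > 25000 nM in this assay, at which 4 of the 4 values shown sit. The compounds shown leave open what change to the shared core, if any, would give an exact number in this assay.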